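The source may hold more compounds than are shown below. What is called first, only, known or untested is meant among the compounds shown, and "the series" means these compounds.

Measured so far in a functional assay on HCT-116 cells (Homo sapiens) for cytotoxicity, read by MTT assay, with a stated time of 72 h; a higher number here means a weaker inhibitor, a lower number a stronger inhibitor:
- compound 1 `O=C(NCc1ccc(F)cc1)c1nc(Br)c2cccnc2c1NCCCNc1c(C(=O)NCc2ccc(F)cc2)nc(Br)c2cccnc12`: > 20000 nM, a limit of the assay rather than a number.
- compound 2 `NCCNc1c(C(=O)NCc2ccc(F)cc2)nc(Br)c2cccnc12`: > 20000 nM, again a limit and not a number.
- compound 3 `C[C@H](CO)Nc1nc(C(=O)NCc2ccc(F)cc2)c(O)c2ncccc12`: "not determined" (no result reported), no result reported.

Compound 2 therefore stands at the limit of this assay, and no measured value on the series distinguishes it from compound 1, which also sits there (the limit of > 20000 nM in this assay, at which 2 of the 3 values shown sit). Within the data shown here, no step between measured compounds is available; the only ordering the data allow is that both reported entries are limits.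

Compound 4 `O=C(NCc1ccc(F)cc1)c1nc(Br)c2cccnc2c1NCCO` is the next compound, not yet measured. It differs from compound 2 as follows: hydroxy in place of amino on a saturated chain carbon, two bonds along the chain from a nitrogen on an aromatic ring. The change is confined to a single heavy atom on the 2-aminoethyl chain.

With compound 2 at the limit, no step beyond the scatter is expected in this assay from such a small change. The step that the limit leaves unreadable from compound 2 to compound 4 is expected to remain within the scatter, most likely with compound 4 again reported as a limit. Compound 4 is estimated at 25000 nM, in the range 8000 nM to 80000 nM.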

Compound 4, half-maximal inhibitory concentration: > 20000 nM
Compound 4 gave a limit, no number; the forecaster's own chance of this, stated with the estimate: 70%; the middle value is on the limit's open side.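

In this assay compound 4 gives > 20000 nM, a limit and not a number. Compound 2 also stands at a limit, so no step can be read between compound 2 and compound 4. The compounds shown leave open whether hydroxy in place of amino alters this read-out at all: the limit of > 20000 nM in this assay, at which 3 of the 4 values shown sit.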